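Swapping furan attachment on a three-aryl pyridine core

The source may hold more compounds than are shown below. What is called first, only, known or untested is meant among the compounds shown, and "the series" means these compounds.

Three compounds of one shared core were tested in a functional assay on DU-145 cells (Homo sapiens) for cytotoxicity, read by CCK-8 assay; a lower number here means a stronger inhibitor, a higher number a weaker inhibitor. Compound 1 `Oc1cccc(-c2cc(-c3cccs3)cc(-c3cccc(O)c3)n2)c1` gives 1630 nM in this assay. Compound 2 `Oc1cccc(-c2cc(-c3ccco3)cc(-c3cccc(O)c3)n2)c1` gives 2150 nM, and compound 3 `Oc1ccc(-c2cc(-c3ccco3)cc(-c3cccc(O)c3)n2)cc1` gives 2070 nM. Compound 2 thus gives the highest of the three numbers, yet its gaps to both neighbours sit within the scatter: the step from compound 1 to compound 2 was a 1.3-fold higher number from compound 1 to compound 2 (0.12 log units; within the scatter), and that from compound 2 to compound 3 was a 1.0-fold lower number from compound 2 to compound 3 (0.02 log units; within the scatter).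

Compound 4 `Oc1cccc(-c2cc(-c3ccoc3)cc(-c3cccc(O)c3)n2)c1` has not yet been measured. It differs from compound 2 in one place: furan-3-yl in place of furan-2-yl on an aromatic carbon. Among the compounds with values here, no measured step shows exactly this change. The closest comparison is the exchange of one five-membered heteroaryl for another from compound 1 to compound 2, which stayed within the scatter, and the shift of the hydroxyl on a phenyl from compound 2 to compound 3 also stayed within the scatter. A step of no more than the scatter is therefore expected here, in either direction. Compound 4 is estimated at 2100 nM in this assay, within a range from 1000 nM to 4500 nM, which means an expected step of a 1.0-fold lower number from compound 2 to compound 4 (0.01 log units; within the scatter).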

Compound 4, half-maximal inhibitory concentration: 1650 nM
Compound 4: middle estimate off by 1.3-fold (0.10 log units), on the high side; the measured number falls inside the stated range.
By their numbers in this assay, from the lowest: compounds 1, 4, 3 and 2 (each within the scatter of the next).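

Moving the attachment point of the furan changes no atoms, only how the ring is joined to the position opposite the ring nitrogen, and in this assay this gives a 1.3-fold lower number from compound 2 to compound 4 (0.11 log units; within the scatter). Replacing thiophen-2-yl with furan-3-yl gives a 1.0-fold higher number from compound 1 to compound 4 (0.01 log units; within the scatter), so this read-out does not separate thiophen-2-yl, furan-2-yl and furan-3-yl at this position. No measurement is available that could explain these small steps.

All the groups shown at this position are five-membered aromatic rings, so it remains open whether an amine, a carboxylic acid or a longer alkyl chain placed there would move the number beyond the scatter. Going by these compounds, it is also open whether furan-3-yl would give a similar number alongside the 4-hydroxyphenyl group of compound 3.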